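Carbamoyl-to-imidazolyl exchange on the core of compound 1

This account rests on a few compounds, and the source may have more. Where it says the series, first, only, none or still open, it means among the compounds named here.

Compound 1 `CCCCN(c1nc2c(C(=O)NC)cccc2o1)[C@H](C)c1ccc(-c2ccccc2-c2nnn[nH]2)cc1` is the weakest inhibitor among the three measured compounds: in a functional assay on CAL1 cells for inhibition of chemerin-like receptor 1 (Homo sapiens), with a stated time of 45 min (a higher number here means a weaker inhibitor, a lower number a stronger inhibitor), compound 1 gives 110 nM. Compound 2 `C[C@H](c1ccc(-c2cc(F)ccc2-c2nc(=O)o[nH]2)cc1)N(CC1CC1)c1nc2c(C(=O)O)cccc2o1` gives 2.3 nM and compound 3 `CCCCN(c1nc2c(C(=O)O)cccc2o1)[C@H](C)c1ccc(-c2cc(Cl)ccc2-c2nc(=O)o[nH]2)cc1` gives 1.2 nM; both gaps to compound 1 lie beyond the scatter, but compounds 2 and 3 differ from compound 1 in more than one place, so no single step can be read from them.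

Compound 4 `CCCCN(c1nc2c(-c3nccn3C)cccc2o1)[C@H](C)c1ccc(-c2ccccc2-c2nnn[nH]2)cc1` keeps everything of compound 1 except one substituent on the shared core: 1-methyl-1H-imidazol-2-yl in place of methylcarbamoyl on an aromatic carbon. The position is unchanged. Among the measured compounds shown here, no measured pair isolates this exchange, and the two other compounds vary it together with other parts, so the direction is uncertain; a change within the scatter, possibly a slight rise, is the working assumption.

Compound 4 is expected to give 150 nM in this assay, with a range of 30 nM to 700 nM. The step of a 1.4-fold higher number from compound 1 to compound 4 (0.13 log units; within the scatter) is estimated to stay within the usual scatter.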

Compound 4, half-maximal inhibitory concentration: 10 nM
Compound 4: the middle estimate sits 15-fold (1.18 log units) above what was measured; measured number outside the range, below it.
By their numbers in this assay, from the lowest: compounds 3 and 2 (each within the scatter of the next); then compound 4; then compound 1.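

In this assay the exchange of methylcarbamoyl for 1-methyl-1H-imidazol-2-yl gives an 11-fold lower number from compound 1 to compound 4 (1.04 log units; beyond the scatter) and is the only single-place step in the series, so this aromatic carbon of the shared core is now shown to influence the read-out strongly. With the butyl chain and the tetrazole-bearing biphenyl part held constant, the amide hydrogen of methylcarbamoyl is not needed for this gain, since the entering group has 0 hydrogen-bond donors and brings a five-membered aromatic ring. No measurement on hand explains the size of this step.

As far as these compounds go, it remains open whether the gain depends on the ring itself or on its methyl group, which an unsubstituted imidazol-2-yl or a 1-methylpyrazol-5-yl at this carbon would separate. Also unresolved is whether the same exchange would hold with the oxadiazolone-bearing, halogen-substituted biphenyl part.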